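The compounds below may be only part of what the source reports. "The series", "measured", "known", "first", "only" and "open" are said of these compounds alone.

In a functional assay on HL-60 cells (Homo sapiens) for antiproliferative activity, read by XTT assay, with a stated time of 72 h (on this read-out lower numbers stand for stronger inhibition and higher numbers for weaker inhibition), compound 1 (`Cc1nc(N)c2c(-c3cccs3)cn([C@@H]3O[C@H](CO)[C@@H](O)[C@H]3O)c2n1`), which carries thiophen-2-yl, gives > 20000 nM, a limit of the assay and not a number. Compound 2 (`Cc1nc(N)c2c(-c3cc4ccccc4o3)cn([C@@H]3O[C@H](CO)[C@@H](O)[C@H]3O)c2n1`), with 1-benzofuran-2-yl, gives > 20000 nM, also a limit. Compound 3 (`C#Cc1cn([C@@H]2O[C@H](CO)[C@@H](O)[C@H]2O)c2nc(C)nc(N)c12`), with ethynyl, gives > 20000 nM, again a limit. Compound 3 therefore has no number of its own and stands with the other two at the limit of > 20000 nM in this assay, at which 3 of the 3 values shown sit.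

Compound 4 (`Cc1nc(N)c2c(I)cn([C@@H]3O[C@H](CO)[C@@H](O)[C@H]3O)c2n1`) has iodo in place of ethynyl on an aromatic carbon. Going by the values given here, three measured steps bear on this change at the same aromatic carbon: a step that the two limits leave unreadable from compound 1 to compound 3, a step that the two limits leave unreadable from compound 2 to compound 3 and a step that the two limits leave unreadable from compound 1 to compound 2. Among the compounds with values here, none has a readable size, so they show only that three different groups there all end at the limit.

No step beyond the scatter, in either direction, is therefore expected in this assay, and the estimate is a number no higher from compound 3 to compound 4 (the limit leaves the size open). The expected value for compound 4 is 20000 nM. The estimated range for compound 4 runs from 5000 nM to 40000 nM.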

Compound 4, half-maximal inhibitory concentration: 2050 nM
Beside the measured number, compound 4's estimate is 9.8-fold (0.99 log units) above it; the measured number lies below the stated range.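

Iodo is the first group at this aromatic carbon that brings the read-out off the limit in this assay: in place of ethynyl it gives an at least 9.7-fold lower number from compound 3 to compound 4 (0.98 log units; beyond the scatter), in place of 1-benzofuran-2-yl it gives an at least 9.7-fold lower number from compound 2 to compound 4 (0.98 log units; beyond the scatter), and in place of thiophen-2-yl it gives an at least 9.7-fold lower number from compound 1 to compound 4 (0.98 log units; beyond the scatter). So this position does not always end at the limit, and the single iodine atom separates compound 4 from the ring groups and the triple bond alike, while the steps among the earlier compounds cannot be read. The other three compounds still hold a limit and not a number: the limit of > 20000 nM in this assay, at which 3 of the 4 values shown sit.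

The compounds shown leave open whether bromo or chloro at this carbon would also leave the limit, or whether only iodo does. They also leave open what a methyl group or an amine would do there, and how large the steps truly are.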